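Moving the Fluorine Around the Benzyl Ring

The source may report more compounds than this note shows. Statements on the series, on what has been measured and on what is new or still open speak of the compounds shown alone.

Compound 3 `N#Cc1cc2c(nc1N1CCC(C(=O)NS(=O)(=O)Cc3ccccc3F)CC1)COC2=O` sits at the weaker end of the measured set. In a functional assay (Platelet, plasma) for inhibition, with Homo sapiens as the target (on this read-out lower numbers stand for stronger inhibition and higher numbers for weaker inhibition), compound 3 gives 23700 nM, the highest of the two numbers available. Its nearest neighbour is compound 2 `N#Cc1cc2c(nc1N1CCC(C(=O)NS(=O)(=O)c3ccc(Cl)s3)CC1)COC2=O`, which in this assay gives 4470 nM; the step of a 5.3-fold higher number from compound 2 to compound 3 (0.72 log units; beyond the scatter) lies beyond the scatter. Among the measured compounds shown here, compound 1 `CC1OC(=O)c2cc(C#N)c(N3CCC(C(=O)NS(=O)(=O)Cc4ccccc4)CC3)nc21` differs from compound 3 in two places at once, so no single step connects them. In this assay compound 1 gives > 300000 nM, which is a limit of the assay rather than a number, namely (the limit of > 300000 nM in this assay, at which 1 of the 3 values shown sits).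

Compound 4 `N#Cc1cc2c(nc1N1CCC(C(=O)NS(=O)(=O)Cc3ccc(F)cc3)CC1)COC2=O` is the next step from compound 3: 4-fluorophenyl in place of 2-fluorophenyl on a saturated chain carbon bound to a sulfonyl sulfur. The two compounds have the same atoms joined differently, so only the placement of the fluorine on the ring changes. For the measured compounds named here, none of the measured steps tests this change directly: the one measured step swaps the whole ring on the sulfonyl sulfur rather than shifting a fluorine on a ring otherwise kept the same. Going by the values given here, with no comparable step measured, the expectation for compound 4 in this assay is a number close to that of compound 3, the step of a 1.2-fold lower number from compound 3 to compound 4 (0.07 log units; within the scatter) being expected to stay within the scatter. Compound 4 is estimated at 20000 nM, between 6000 nM and 70000 nM.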

Compound 4, half-maximal inhibitory concentration: 3500 nM
Compound 4: the middle estimate sits 5.7-fold (0.76 log units) above what was measured, outside the stated range (below it).
By their numbers in this assay, from the lowest: compounds 4 and 2 (each within the scatter of the next); then compound 3. At a limit, above all of these: compound 1.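

Moving the fluorine alone matters in this assay: with the same atoms and only their joining changed, the switch from 2-fluorophenyl to 4-fluorophenyl on a saturated chain carbon bound to a sulfonyl sulfur gives a 6.8-fold lower number from compound 3 to compound 4 (0.83 log units; beyond the scatter) and so shows that the placement on the ring counts, not only the choice of ring. The wider swap on the sulfonyl sulfur now reads differently too, with a 1.3-fold lower number from compound 2 to compound 4 (0.11 log units; within the scatter) and thus no separation between 4-fluorobenzyl and 5-chlorothiophen-2-yl, so a fluorobenzyl group as such does not go with the higher number of compound 3. Nothing measured among these compounds accounts for the gap between the two fluorine placements.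

Compound 1 gives > 300000 nM as a limit of the assay and differs from compound 4 in two places at once, so it cannot show whether the fluorine itself is needed. Going by these compounds, whether a chlorine atom or a methoxy group in place of the fluorine of 4-fluorobenzyl would keep the number of compound 4 also stays open.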